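The source may report more compounds than this note shows. Statements on the series, on what has been measured and on what is new or still open speak of the compounds shown alone.

Compound 3 `O=C(NCc1ccc(CNS(=O)(=O)c2ccccc2)cc1)c1ccc([N+](=O)[O-])cc1` gives 100 nM in an assay on MDA-MB-231 cells for binding affinity to C-X-C chemokine receptor type 4 (Homo sapiens), read by immunofluorescence and microscopy, with stated times of 10 min and 30 min; a higher number here means that more compound is needed for the effect, a lower number that less compound is needed. It stands level with compound 1 `O=C(NCc1ccc(CNS(=O)(=O)c2ccccc2)cc1)c1ccc(F)cc1`, which in this assay gives 100 nM, and together the two hold the lowest numbers of the three, while compound 2 `COc1ccc(C(=O)NCc2ccc(CNS(=O)(=O)c3ccccc3)cc2)cc1` gives 1000 nM, the step being a 10-fold lower number from compound 2 to compound 3 (1.00 log units; beyond the scatter). The change to compound 4 `O=C(NCc1ccc(CNS(=O)(=O)c2ccccc2)cc1)c1cccc(Cl)c1` is 3-chlorophenyl in place of 4-nitrophenyl on a carbonyl carbon. For the measured compounds named here, the steps that bear on it are no change at the digits printed from compound 1 to compound 3 (within the scatter) and a 10-fold higher number from compound 1 to compound 2 (1.00 log units; beyond the scatter): one swap on that ring left the number unchanged, the other raised it modestly, so a modest rise or none beyond the scatter is expected, as a 2.0-fold higher number from compound 3 to compound 4 (0.30 log units; within the scatter). For compound 4 the expected value in this assay is 200 nM, within 60 nM to 1000 nM.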

Compound 4, effective concentration (reported as EC, without a stated level of effect): 1000 nM
Compound 4: the middle estimate sits 5.0-fold (0.70 log units) below what was measured, within the range that was stated.
By their numbers in this assay, from the lowest: compounds 1 and 3 (each within the scatter of the next); then compounds 2 and 4 (each within the scatter of the next).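

On the ring held by the carbonyl carbon, the 3-chlorophenyl group does not stay with the lower pair in this assay: the result is a 10-fold higher number from compound 3 to compound 4 (1.00 log units; beyond the scatter) and a 10-fold higher number from compound 1 to compound 4 (1.00 log units; beyond the scatter), but no change at the digits printed from compound 2 to compound 4 (within the scatter). Two of the three swaps from 4-nitrophenyl or its fluoro counterpart now raise the number, so this position is not indifferent to its substituent. Nothing measured here explains this.

Compound 4 changes both the group and its place on the ring, so the two effects cannot be separated. From the compounds shown here alone, how an amine or a carboxylic acid on this ring would behave remains open.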